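Isopropyl esters in the shared core: thoracic aorta read-out

The compounds below may be only part of what the source reports. "The series", "measured", "known", "first", "only" and "open" are said of these compounds alone.

Measured so far:
compound 1, `CCOC(=O)C1=C(C)NC(SC)=NC1c1cccc([N+](=O)[O-])c1`: 130 nM
compound 2, `CCOC(=O)C1=C(C)NC(SC)=NC1c1cccc(Cl)c1Cl`: 16 nM
compound 3, `CSC1=NC(c2cccc([N+](=O)[O-])c2)C(C(=O)OC(C)C)=C(C)N1`: 7 nM

In a functional assay (thoracic aorta) with Oryctolagus cuniculus as the target (on this read-out lower numbers stand for stronger inhibition and higher numbers for weaker inhibition), compound 1 gives 130 nM and compound 3 gives 7 nM. The change between them, (methyl in place of hydrogen on a saturated chain carbon bound to an oxygen next to a carbonyl group and a saturated chain carbon), made a 19-fold lower number from compound 1 to compound 3 (1.27 log units; beyond the scatter). Compound 2 differs from compound 1 in the aryl part; the difference between the two cores is not broken down here, and the two values show compound 2 with the lower number in this assay, 16 nM, while compound 1 gives 130 nM.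

Compound 4, `CSC1=NC(c2cccc(Cl)c2Cl)C(C(=O)OC(C)C)=C(C)N1`, is not yet measured. It relates to compound 2 as compound 3 relates to compound 1: the change is methyl in place of hydrogen on a saturated chain carbon bound to an oxygen next to a carbonyl group and a saturated chain carbon, the same change at the same place, occurring twice among the compounds shown. Among the measured compounds shown here, only one measured pair carries it, so the size of the second step rests on one observation, made from a weaker starting point.

For compound 4 in this assay the expected step is an 8.0-fold lower number from compound 2 to compound 4 (0.90 log units; beyond the scatter), somewhat smaller than the earlier one because the same change gave a 19-fold lower number from compound 1 to compound 3 (1.27 log units; beyond the scatter) from a higher starting number, and compound 2 already stands with a low number. Compound 4 is estimated at 2 nM, with a range from 0.5 nM to 8 nM.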

Compound 4, half-maximal inhibitory concentration: 6 nM
Compound 4: middle estimate off by 3.0-fold (0.48 log units), on the low side; low and high end bracket the measured number.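

In this assay, the change from ethoxycarbonyl to isopropoxycarbonyl gives a 2.7-fold lower number from compound 2 to compound 4 (0.43 log units; beyond the scatter), so the direction seen on the core of compound 1 holds on the core of compound 2, but the size does not carry over: the same change on two cores in this assay, a 19-fold lower number (1.27 log units; beyond the scatter) from compound 1 to compound 3 and a 2.7-fold lower number (0.43 log units; beyond the scatter) from compound 2 to compound 4, 7.0-fold (0.84 log units) apart, beyond the scatter of two such steps

With the isopropyl ester in place, the two aryl parts give similar numbers, compound 3 at 7 nM and compound 4 at 6 nM, while the ethyl esters stand further apart. These two pairs support only the direction of the change on these two cores; they do not explain why the sizes differ, and they give no basis for a step size on a third aryl part.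

The compounds shown leave open whether the trend continues beyond isopropyl, for example to a tert-butyl ester or a longer chain such as n-butyl. They also leave open how a carboxylic acid or an amide would read at the same place, and whether any ester on either core can fall further than the numbers seen for compound 3 and compound 4.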